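Working notes: pendant bicycle swap on the shared core

The source may report more compounds than this note shows. Statements on the series, on what has been measured and on what is new or still open speak of the compounds shown alone.

Measured so far:
compound 1 `O=S(=O)(Nc1cc(-c2ccc3sncc3c2)cnc1Cl)c1ccc(F)cc1` — > 12000 nM
compound 2 `O=S(=O)(Nc1cc(-c2ccc3nccn3c2)cnc1Cl)c1ccc(F)cc1` — 574 nM

In an assay on U-87MG ATCC cells for inhibition of RAC-alpha serine/threonine-protein kinase (Homo sapiens), read by AlphaScreen, with a stated time of 2 h (a higher number here means a weaker inhibitor, a lower number a stronger inhibitor), compound 1 gives > 12000 nM, which is a limit of the assay and not a number (the limit of > 12000 nM in this assay, at which 1 of the 2 values shown sits). In this assay, for the measured compounds named here, compound 2 gives 574 nM, the only number obtained so far. Going by the values given here, the single measured step is an at least 20-fold lower number from compound 1 to compound 2 (1.32 log units; beyond the scatter), a swap of one bicycle for another on the shared core.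

Compound 3 `O=S(=O)(Nc1cc(-c2ccc3nccn3n2)cnc1Cl)c1ccc(F)cc1` differs from compound 2 by a group of 9 heavy atoms (6 carbon, 3 nitrogen; one five-membered aromatic ring with 2 hetero atoms, one six-membered aromatic ring with 2 hetero atoms) in place of a group of 9 heavy atoms (7 carbon, 2 nitrogen; one five-membered aromatic ring with 2 hetero atoms, one six-membered aromatic ring with 1 hetero atom), on an aromatic carbon. Among the compounds with values here, no measured step covers this change directly: the step of an at least 20-fold lower number from compound 1 to compound 2 (1.32 log units; beyond the scatter) exchanges a different pair of bicycles, so it shows only that the pendant bicycle can move the number strongly. For compound 3 the expectation is a step close to the scatter, a 1.4-fold higher number from compound 2 to compound 3 (0.14 log units; within the scatter). Compound 3 is therefore estimated at 800 nM, with a range from 200 nM to 3500 nM.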

Compound 3, half-maximal inhibitory concentration: 50 nM
Beside the measured number, compound 3's estimate is 16-fold (1.20 log units) above it; the measured number lies below the stated range.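

In this assay the pendant bicycle proves sensitive even to a change in one ring: a six-membered aromatic ring with 2 hetero atoms in place of one with 1 hetero atom, with a five-membered aromatic ring with 2 hetero atoms on both sides, gives an 11-fold lower number from compound 2 to compound 3 (1.06 log units; beyond the scatter) as a large step of its own. Against the sulfur-bearing bicycle, the same group gives an at least 240-fold lower number from compound 1 to compound 3 (2.38 log units; beyond the scatter), a wider span at this position than the first step showed. Compound 1 stands at a limit of the assay and not at a number: the limit of > 12000 nM in this assay, at which 1 of the 3 values shown sits.

Open, on these data alone, is whether an amine or a methoxy group on the bicycle of compound 3 keeps the low number. Also open, as far as these compounds go, is whether the step between these bicycles holds with a methyl group in place of the chloro group on the shared core.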